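Changing the sulfonamide ring: compound 2 to compound 3

A few compounds are considered here, and "the series" means these few. Any claim that something is new, unique, unknown or untested is made for them only; others in the source may bear on it.

- compound 1 `O=S(=O)(Nc1ncccn1)c1ccc(Nc2nncc3ccccc23)cc1` gives 14 nM
- compound 2 `O=S(=O)(Nc1nccs1)c1ccc(Nc2nncc3ccccc23)cc1` gives 15 nM

Both numbers come from a functional assay on HeLa cells (Homo sapiens) for antiproliferative activity, read by sulforhodamine B assay, with a stated time of 72 h (a lower number here means a stronger inhibitor, a higher number a weaker inhibitor), and lie within the scatter of each other, so compound 2 stands level with compound 1. Compound 3 `Cc1cc(NS(=O)(=O)c2ccc(Nc3nncc4ccccc34)cc2)no1` has not yet been measured. It carries 5-methyl-1,2-oxazol-3-yl in place of 1,3-thiazol-2-yl on a sulfonamide nitrogen. Within the data shown here, only one measured step bears on this place: a 1.1-fold higher number from compound 1 to compound 2 (0.03 log units; within the scatter). That single exchange of one ring for another changed nothing measurable, so no shift beyond the scatter is expected here either. Among the measured compounds shown here, no measured compound carries the 5-methyl-1,2-oxazol-3-yl group, so the expected range stays wide. The expected change in this assay is a 1.2-fold higher number from compound 2 to compound 3 (0.08 log units; within the scatter). For compound 3 the estimated value is 18 nM, with an expected range from 7 nM to 50 nM as the limits.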

Compound 3, half-maximal inhibitory concentration: 13 nM
The estimate for compound 3 lay 1.4-fold (0.14 log units) above the measured number; the measured number falls inside the stated range.
By their numbers in this assay, from the lowest: compounds 3, 1 and 2 (each within the scatter of the next).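

In this assay, the third ring on the sulfonamide nitrogen leaves the picture as it was, both against the thiazole (a 1.2-fold lower number from compound 2 to compound 3 (0.06 log units; within the scatter)) and against the pyrimidine (a 1.1-fold lower number from compound 1 to compound 3 (0.03 log units; within the scatter)). Among these compounds, the earlier pair showed only that two unsubstituted rings stand level; 5-methyl-1,2-oxazol-3-yl adds a methyl group and brings oxygen in place of sulfur, and the number still stays within the scatter. Nothing available explains why these three compounds stand level.

All three groups shown are aromatic rings, so it remains open whether a plain hydrogen, a cyclohexyl ring or a chain ending in a carboxylic acid would be tolerated on this nitrogen. On these data alone, it is also open whether larger groups on the ring, such as a phenyl, would separate the numbers.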